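This account rests on a few compounds, and the source may have more. Where it says the series, first, only, none or still open, it means among the compounds named here.

Working notes on the series. Compound 1 `CC(C)C(NC(=O)NO)C(=O)NC1CCCCC1` and compound 2 `CCC(C)C(NC(=O)NO)C(=O)NC1CCCCC1` share one core; compound 3 `CC(C)C(NC(=O)n1nnc2ccccc21)C(=O)NC1CCCC1` and compound 4 `CCC(C)C(NC(=O)n1nnc2ccccc21)C(=O)NC1CCCC1` share another, and the difference between the two cores is not broken down here. In a functional assay on L1210 cells (Mus musculus) for inhibition (on this read-out lower numbers stand for stronger inhibition and higher numbers for weaker inhibition), compound 1 gives only a limit of the assay, > 100000 nM. Compound 2 gives 89000 nM in this assay. The change from compound 1 to compound 2 is methyl in place of hydrogen on a saturated chain carbon, three bonds along the chain from an amide-type nitrogen and a carbonyl carbon, and the measured step was an at least 1.1-fold lower number from compound 1 to compound 2 (0.05 log units; that floor lies within the scatter); since the starting value was a limit of > 100000 nM in this assay, at which 1 of the 3 values shown sits, only the floor of that step is known. Compound 3 gives only a limit of the assay in this assay, > 200000 nM. Compound 4 carries the same change, (methyl in place of hydrogen on a saturated chain carbon, three bonds along the chain from an amide-type nitrogen and a carbonyl carbon), on the core of compound 3, at a place described in the same words. Within the data shown here, the one measured instance of this change gave an at least 1.1-fold lower number from compound 1 to compound 2 (0.05 log units; that floor lies within the scatter), a floor within the scatter, and compound 3 sits at a limit (the limit of > 200000 nM in this assay, at which 1 of the 3 values shown sits). For compound 4 a step that the limit leaves unreadable from compound 3 to compound 4 is therefore expected, with a fair chance that the assay again reports only a limit. Compound 4 is expected to give about 250000 nM in this assay.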

Compound 4, half-maximal inhibitory concentration: 102000 nM
For compound 4 the middle estimate is 2.5-fold (0.39 log units) above the measured one; the measured number falls inside the stated range.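

In this assay the change reads as an at least 1.9-fold lower number from compound 3 to compound 4 (0.29 log units; that floor lies within the scatter), and set beside the same change on the other core it stands thus: the same change on two cores in this assay, an at least 1.1-fold lower number (0.05 log units; that floor lies within the scatter) from compound 1 to compound 2 and an at least 1.9-fold lower number (0.29 log units; that floor lies within the scatter) from compound 3 to compound 4; the limit leaves it open whether they differ

Compound 3, the start of the new step, is a limit of the assay: the limit of > 200000 nM in this assay, at which 1 of the 4 values shown sits.

Read together, the two steps agree in direction only: each is known as a floor within the scatter, so the notes show neither the true size of either step nor that methyl in place of hydrogen carries from one core to the other with the same size.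

Open, as far as these compounds go, is how a longer chain than sec-butyl, or an amine or a carboxylic acid on that saturated chain carbon, would read in this assay. Also open, from the compounds shown here alone, is how large the step would be on either core if it started from a compound that gives a number and not a limit.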